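Swapping Fluoro for Cyano in a Cytotoxic Series

The source may hold more compounds than are shown below. What is called first, only, known or untested is meant among the compounds shown, and "the series" means these compounds.

Among the measured compounds shown here, compound 2 `O=[N+]([O-])c1ccc(CN2CCC(n3cc(CC(OCc4cc(-c5cccc(F)c5)no4)c4ccc(Br)cc4)nn3)CC2)cc1` is the only member of this small set with a measured number: in a functional assay on MDA-MB-231 cells (Homo sapiens) for cytotoxicity, with a stated time of 48 h (on this read-out lower numbers stand for stronger inhibition and higher numbers for weaker inhibition), compound 2 gives 5000 nM. Compound 1 `O=[N+]([O-])c1ccc(CN2CCC(n3cc(CC(OCc4cc(-c5ccc(Br)cc5)no4)c4ccc(Br)cc4)nn3)CC2)cc1` differs from it at a single aromatic ring, carrying 4-bromophenyl where compound 2 carries 3-fluorophenyl. For compound 1 the result in this assay is a limit, > 25000 nM. For the measured compounds named here, the one measured step, an at least 5.0-fold lower number from compound 1 to compound 2 (0.69 log units; beyond the scatter), therefore rests on one side on (the limit of > 25000 nM in this assay, at which 1 of the 2 values shown sits). Compound 3 `N#Cc1cccc(-c2cc(COC(Cc3cn(C4CCN(Cc5ccc([N+](=O)[O-])cc5)CC4)nn3)c3ccc(Br)cc3)on2)c1` is not yet measured; it keeps everything of compound 2 except (cyano in place of fluoro on an aromatic carbon). Going by the values given here, no measured step touches this particular exchange: the only comparison available replaced the whole 4-bromophenyl with 3-fluorophenyl, and nothing shows how fluoro and cyano compare on a ring that is otherwise kept. With no evidence pointing in either direction, the expectation for compound 3 is a step that stays within the usual scatter, no change at the digits printed from compound 2 to compound 3 (within the scatter). Compound 3 is accordingly estimated at 5000 nM, with a range from 1800 nM to 15000 nM.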

Compound 3, half-maximal inhibitory concentration: > 25000 nM
Compound 3: no number, only a limit (the forecaster's own chance of this, stated with the estimate: 15%); middle value at least 5.0-fold (0.69 log units) away from the limit.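

With the ring and the position kept and only the group changed, cyano in place of fluoro gives an at least 5.0-fold higher number from compound 2 to compound 3 (0.69 log units; beyond the scatter) in this assay, which means weaker inhibition. The earlier step replaced 4-bromophenyl with 3-fluorophenyl and so changed the group and its place together, whereas this exchange shows that the group at this one position matters on its own, with 3-fluorophenyl the only ring among those shown that gives a measured number. Compound 3 carries a limit and not a number, so the full size of its step from compound 2 stays unknown, and the step between compound 1 and compound 3 cannot be read: the limit of > 25000 nM in this assay, at which 2 of the 3 values shown sit.

The compounds shown leave open whether other groups at this position, such as chloro, methoxy or an amine, would match compound 2 or give stronger inhibition. They also leave open what a plain hydrogen in place of fluoro would give, and so whether fluoro adds anything to the ring or the cyano group alone takes something away.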